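The source may report more compounds than this note shows. Statements on the series, on what has been measured and on what is new or still open speak of the compounds shown alone.

Measured compounds:
compound 1 `COc1ccc(-c2cnc(NC(=O)c3cnco3)n2C)cc1`: > 100000 nM
compound 2 `Cn1c(-c2ccc(C#N)cc2)cnc1NC(=O)c1ccc(F)cc1`: > 50000 nM

Both compounds were tested in a toxicity assay on THP-1 cells (Homo sapiens) for inhibition; on this read-out lower numbers stand for higher toxicity in this test and higher numbers for lower toxicity in this test. For compound 1 the result in this assay is a limit of the test and not a number, > 100000 nM. For compound 2 the result in this assay is likewise a limit and not a number, > 50000 nM. Compound 1 therefore stands at the upper edge of what this assay can report, (the limit of > 100000 nM in this assay, at which 1 of the 2 values shown sits), and nothing among the two values shown separates it from compound 2, (the limit of > 50000 nM in this assay, at which 1 of the 2 values shown sits).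

Compound 3 `COc1ccc(-c2cnc(NC(=O)C3CCOCC3)n2C)cc1` is not yet measured. It differs from compound 1 in one place: oxan-4-yl in place of 1,3-oxazol-5-yl on a carbonyl carbon. Going by the values given here, no measured pair differing in one place is available, so the size of this step cannot be read from the data. Given that compound 1 sits at the limit, (the limit of > 100000 nM in this assay, at which 1 of the 2 values shown sits), the expected step in this assay is none beyond the scatter, and the step of a number no higher from compound 1 to compound 3 (the limit leaves the size open) is expected to be flat. Compound 3 is estimated to give 100000 nM in this assay, within 30000 nM to 300000 nM, most likely again as a limit rather than a number.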

Compound 3, half-maximal cytotoxic concentration: > 100000 nM
Compound 3 ended at the assay's limit (the forecaster's own chance of this, stated with the estimate: 85%); the middle value sits exactly at the limit.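

In this assay compound 3 gives > 100000 nM, a limit of the test and not a number. Going by these compounds alone, compound 1 also stands at a limit, so no step from compound 1 to compound 3 can be read. The compounds shown leave open what number, if any, oxan-4-yl or 1,3-oxazol-5-yl on the carbonyl carbon would give in this assay.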